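Swapping Ethyl for Hydrogen on Compound 2

This account rests on a few compounds, and the source may have more. Where it says the series, first, only, none or still open, it means among the compounds named here.

Three related compounds have entries in an ADME assay on HeLa cells (Homo sapiens) for inhibition, read by MTT assay, with a stated time of 48 h (a higher number here means a weaker inhibitor, a lower number a stronger inhibitor), yet only one carries a result. Compound 1 `C/C=C/Cn1cc(/C=C/C(=O)CC(=O)C(=O)OCC)c2ccccc21` stands at "not determined" (no result reported). Compound 3 `CCOC(=O)C(=O)CC(=O)/C=C/c1cn(Cc2ccc(OC)cc2)c2ccccc12` stands at "not determined" (no result reported). Compound 2 `CCOC(=O)C(=O)CC(=O)/C=C/c1cn(Cc2ccccc2)c2ccccc12` gives > 40000 nM, which is a limit of the assay and not a number. The record so far comes down to the limit of > 40000 nM in this assay, at which 1 of the 3 values shown sits.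

The next compound, compound 4 `O=C(/C=C/c1cn(Cc2ccccc2)c2ccccc12)CC(=O)C(=O)O`, changes one place in compound 2: hydrogen in place of ethyl on an oxygen next to a carbonyl group. The same change reads as ethoxy to hydroxy. Among the measured compounds shown here, no measured pair shows what this swap does, so the expectation in this assay is no step beyond the usual scatter, in either direction. That expectation rests only on compound 2 at > 40000 nM, again a limit. The expected shift is small, and the estimated step is a step that the limit leaves unreadable from compound 2 to compound 4. The assay may well report only a limit again. For compound 4 the expected value is about 50000 nM, with an estimated range from 15000 nM to 120000 nM.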

Compound 4, half-maximal inhibitory concentration: > 40000 nM
Compound 4: no number, only a limit; the forecaster's own chance of this, stated with the estimate: 70%; the middle value is on the limit's open side.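

Among the compounds shown here, compound 2 and compound 4 both return only a limit in this assay, so no step between them can be read: the limit of > 40000 nM in this assay, at which 2 of the 4 values shown sit. The compounds shown leave open whether ethoxy to hydroxy shifts inhibition at all, and how strongly either compound inhibits.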